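The source may hold more compounds than are shown below. What is called first, only, known or untested is meant among the compounds shown, and "the series" means these compounds.

Within the data shown here, in a functional assay on MCF7 cells (Homo sapiens) for cytotoxicity (on this read-out lower numbers stand for stronger inhibition and higher numbers for weaker inhibition), compound 2 `CCCCCCCCC[C@@H]1CC(=O)N[C@H](CC(C)C)C(=O)N[C@@H](CO)C(=O)N[C@@H]([C@@H](C)O)C(=O)N[C@H](CC(C)C)C(=O)N[C@@H]([C@@H](C)CC)C(=O)O1` gives 3000 nM and stands at the low end of the two numbers known, with compound 1 `CCCCCCC[C@@H]1CC(=O)N[C@H](CC(C)C)C(=O)N[C@@H](CO)C(=O)N[C@@H]([C@@H](C)O)C(=O)N[C@H](CC(C)C)C(=O)N[C@@H]([C@@H](C)CC)C(=O)O1` at 4000 nM within the scatter of it. Compound 3 `CC[C@H](C)[C@@H]1NC(=O)[C@@H](CC(C)C)NC(=O)[C@H]([C@@H](C)O)NC(=O)[C@H](CO)NC(=O)[C@@H](CC(C)C)NC(=O)C[C@@H](CCCCCCC(C)C)OC1=O` carries isopropyl in place of propyl on a saturated chain carbon, six bonds along the chain from a saturated ring carbon. Among the measured compounds shown here, the only measured step in this assay, a 1.3-fold lower number from compound 1 to compound 2 (0.12 log units; within the scatter), also altered that chain and stayed within the scatter, so nothing in the data points to a shift of any size. The step of no change at the digits printed from compound 2 to compound 3 (within the scatter) is therefore estimated as none beyond the scatter. For compound 3 a value of 3000 nM is expected, within 1500 nM to 6000 nM.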

Compound 3, half-maximal inhibitory concentration: 6000 nM
The estimate for compound 3 lay 2.0-fold (0.30 log units) below the measured number; measured number inside the range.
By their numbers in this assay, from the lowest: compounds 2, 1 and 3 (each within the scatter of the next).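

At this position in this assay, isopropyl in place of propyl gives a 2.0-fold higher number from compound 2 to compound 3 (0.30 log units; within the scatter), and isopropyl in place of methyl gives a 1.5-fold higher number from compound 1 to compound 3 (0.18 log units; within the scatter). A branched chain end therefore stays within the scatter here, as the lengthened chain did, which the earlier pair, differing only in chain length, could not show. No evidence on hand bears on this result. Open, as far as these compounds go, is whether a chain end carrying an amine or a carboxylic acid, or a much longer chain, would move the number beyond the scatter.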